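Notes on the group between the ring nitrogens

This account rests on a few compounds, and the source may have more. Where it says the series, first, only, none or still open, it means among the compounds named here.

Measured so far:
compound 1 `CCOC(=O)c1cnc(SC)nc1NN1C(=O)C=C(C)C1=O`: in a functional assay on Jurkat cells for inhibition of nuclear factor NF-kappa-B complex (Homo sapiens) (a higher number here means a weaker inhibitor, a lower number a stronger inhibitor), compound 1 gives 200 nM
compound 2 `CCOC(=O)c1cnc(-c2ccsc2)nc1NN1C(=O)C=C(C)C1=O`: in this assay compound 2 gives 100 nM
compound 3 `CCOC(=O)c1cnc(-c2ccc(C)s2)nc1NN1C(=O)C=C(C)C1=O`: in this assay compound 3 gives 200 nM

All three share the same core and differ only in the group on the aromatic carbon between two ring nitrogen atoms. Compound 3 stands level with compound 1 at the digits shown, the two together the highest of the three numbers. Within the scatter too is the step of a 2.0-fold higher number from compound 2 to compound 3 (0.30 log units; within the scatter). The other steps are equally small: a 2.0-fold lower number from compound 1 to compound 2 (0.30 log units; within the scatter) and no change at the digits printed from compound 1 to compound 3 (within the scatter). Nothing among the three moves beyond the scatter.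

Compound 4 `CCOC(=O)c1cnc(Cc2ccccc2)nc1NN1C(=O)C=C(C)C1=O` takes the next step: benzyl in place of 5-methylthiophen-2-yl on an aromatic carbon. Within the data shown here, no measured step covers a benzyl at this place; the steps that bear on it are those that exchanged one group for another at the same aromatic carbon, all within the scatter. On that basis no step beyond the scatter is expected in this assay for compound 4, and the estimate is set at the level of compound 3. The range is kept wide; only three points are known and none carries a benzyl. Compound 4 is expected to give 200 nM (70 nM to 600 nM). The step of no change at the digits printed from compound 3 to compound 4 (within the scatter) is thus expected to stay within the scatter.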

Compound 4, half-maximal inhibitory concentration: 7000 nM
The estimate for compound 4 lay 35-fold (1.54 log units) below the measured number; the whole stated range lies below it.
By their numbers in this assay, from the lowest: compounds 2, 1 and 3 (each within the scatter of the next); then compound 4.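

In this assay this position proves sensitive to the group it carries: the change gives a 35-fold higher number from compound 3 to compound 4 (1.54 log units; beyond the scatter) and a 70-fold higher number from compound 2 to compound 4 (1.85 log units; beyond the scatter) and a 35-fold higher number from compound 1 to compound 4 (1.54 log units; beyond the scatter) while methylsulfanyl, thiophen-3-yl and 5-methylthiophen-2-yl remain within the scatter of one another. The tolerance seen among those three groups therefore does not extend to benzyl, and the series now holds one group on this aromatic carbon that stands clearly apart from the rest. Going by these compounds, because benzyl differs from 5-methylthiophen-2-yl in both its ring and its attachment through a carbon chain atom, these compounds cannot show which difference goes with the higher number, and it remains open how a directly attached phenyl, a thiophen-2-ylmethyl, a 2-phenylethyl chain or an amine would behave here. No available measurement accounts for the step.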